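Chloro for Hydroxy: From Compound 1 to Compound 3

A few compounds are considered here, and "the series" means these few. Any claim that something is new, unique, unknown or untested is made for them only; others in the source may bear on it.

Measured so far:
compound 1 `O=C1Nc2ccc(S(=O)(=O)N3CCOCC3)cc2/C1=N/c1ccc(O)cc1` — 27300 nM
compound 2 `O=C1Nc2ccc(S(=O)(=O)N3CCOCC3)cc2/C1=N/NS(=O)(=O)c1ccccc1` — 13300 nM

In a functional assay on HCT-116 cells (Homo sapiens) for cytotoxicity, read by sulforhodamine B assay, with a stated time of 24 h (on this read-out higher numbers stand for weaker inhibition and lower numbers for stronger inhibition), compound 1 gives the highest of the two numbers; compound 2 stands nearest, with a 2.1-fold lower number from compound 1 to compound 2 (0.31 log units; beyond the scatter). Compound 3 `O=C1Nc2ccc(S(=O)(=O)N3CCOCC3)cc2/C1=N/c1ccc(Cl)cc1` differs from compound 1 by chloro in place of hydroxy on an aromatic carbon. Among the compounds with values here, no measured step tests this change: the single step available concerns a different replacement on the double-bonded nitrogen, (phenylsulfonyl)amino in place of 4-hydroxyphenyl, and is modest in size. With nothing directly comparable, compound 3 is expected to show only a 1.4-fold lower number from compound 1 to compound 3 (0.14 log units; within the scatter) in this assay. The estimate for compound 3 is 20000 nM, in the range 8000 nM to 50000 nM.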

Compound 3, half-maximal inhibitory concentration: 24300 nM
The estimate for compound 3 lay 1.2-fold (0.08 log units) below the measured number, within the range that was stated.
By their numbers in this assay, from the lowest: compounds 2, 3 and 1 (each within the scatter of the next, the first and the last beyond it).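

In this assay, chloro in place of hydroxy on an aromatic carbon, para to a large group, gives a 1.1-fold lower number from compound 1 to compound 3 (0.05 log units; within the scatter) and so does not separate compound 3 from compound 1, although the hydrogen-bond donor and acceptor counted for hydroxy are gone. The second comparison gives a 1.8-fold higher number from compound 2 to compound 3 (0.26 log units; within the scatter) and does not separate 4-chlorophenyl from (phenylsulfonyl)amino on the double-bonded nitrogen either. Nothing measured here bears on the reason for this result.

Going by these compounds, an amine or a carboxylic acid at this place remains open, as does whether any such group would separate from hydroxy and chloro.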